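A Fluorine Added to an Already Harmless Amide

The source may hold more compounds than are shown below. What is called first, only, known or untested is meant among the compounds shown, and "the series" means these compounds.

Compound 1 `CN(C)c1cc2[nH]c(C3CCCCC3)nc2cc1NC(=O)c1ccc(OC(F)F)cc1` was tested in an ADME assay on Vero cells (Chlorocebus sabaeus) for cytotoxicity, read by resazurin assay, with a stated time of 3 days; a lower number here means a stronger inhibitor, a higher number a weaker inhibitor. In this assay compound 1 gives > 100 ug/mL, which is a limit of the assay and not a number. Compound 2 `CN(C)c1cc2[nH]c(C3CCCCC3)nc2cc1NC(=O)c1cccc(Br)c1` carries a 3-bromophenyl on the carbonyl carbon instead of the 4-(difluoromethoxy)phenyl of compound 1. In this assay compound 2 gives > 100 ug/mL, again a limit. Compound 3 `CN(C)c1cc2[nH]c(C3CCCCC3)nc2cc1NC(=O)c1ccco1` carries a furan-2-yl on that carbon. In this assay compound 3 gives > 100 ug/mL, also a limit. The steps between them are therefore a step that the two limits leave unreadable from compound 1 to compound 2, a step that the two limits leave unreadable from compound 1 to compound 3 and a step that the two limits leave unreadable from compound 2 to compound 3. Compound 1 thus stands only at a limit, as do its two neighbours; what the three share is the limit of > 100 ug/mL in this assay, at which 3 of the 3 values shown sit.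

Compound 4 `CN(C)c1cc2[nH]c(C3CCCCC3)nc2cc1NC(=O)c1ccc(OC(F)(F)F)cc1` differs from compound 1 by fluoro in place of hydrogen on a saturated chain carbon bound to two fluorine atoms and an oxygen on an aromatic ring. Among the compounds with values here, none of the measured steps reads as a number, so none gives a direction for this change; all three swaps of the whole ring on the carbonyl carbon left the read-out at the limit, and the change from compound 1 to compound 4 is a smaller alteration than any of them. Compound 4 is therefore expected to sit at the limit as well, with a step that the limit leaves unreadable from compound 1 to compound 4 expected to be nothing beyond the scatter. The estimate for compound 4 is 150 ug/mL, within a range from 80 ug/mL to 300 ug/mL.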

Compound 4, half-maximal inhibitory concentration: > 100 ug/mL
Compound 4: no number, only a limit (the forecaster's own chance of this, stated with the estimate: 85%); the middle value lies beyond the limit too.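

Compound 4, like compound 1, gives only a limit, so no size can be read for the step between them or for any other step among compounds 1 to 4. All four share one result: the limit of > 100 ug/mL in this assay, at which 4 of the 4 values shown sit.

Still open, from the compounds shown here alone, is where each compound's true value lies beyond that limit in this assay, and whether these compounds differ from one another at all.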